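The source may report more compounds than this note shows. Statements on the series, on what has been measured and on what is new or still open speak of the compounds shown alone.

In a functional assay on HT-29 cells (Homo sapiens) for antiproliferative activity, read by MTT assay, with a stated time of 72 h (on this read-out higher numbers stand for weaker inhibition and lower numbers for stronger inhibition), compound 1 `Cc1ccc(N2CCN(C(=S)SCc3ccc4nc(N)nc(N)c4c3)CC2)cc1` gives 3020 nM and compound 2 `Nc1nc(N)c2cc(CSC(=S)N3CCN(c4ccccc4Cl)CC3)ccc2n1` gives 3900 nM, two numbers that lie within the usual scatter of each other. Compound 3 `Nc1nc(N)c2cc(CSC(=S)N3CCN(c4ccc(Cl)c(Cl)c4)CC3)ccc2n1` has 3,4-dichlorophenyl in place of 2-chlorophenyl on an amine nitrogen in a ring. Going by the values given here, the only measured step at this place, a 1.3-fold higher number from compound 1 to compound 2 (0.11 log units; within the scatter), also exchanged one substituted phenyl for another and was small. A similarly small change is therefore expected in this assay, and the estimated step, a 1.1-fold lower number from compound 2 to compound 3 (0.05 log units; within the scatter), stays within the scatter with no firm direction. For compound 3 the expected value is 3500 nM, with an estimated range of 1400 nM to 8500 nM.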

Compound 3, half-maximal inhibitory concentration: 3480 nM
For compound 3 the middle estimate is 1.0-fold (0.00 log units) above the measured one; low and high end bracket the measured number.
By their numbers in this assay, from the lowest: compounds 1, 3 and 2 (each within the scatter of the next).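

In this assay the change to 3,4-dichlorophenyl gives a 1.1-fold lower number from compound 2 to compound 3 (0.05 log units; within the scatter) and, measured against the 4-methylphenyl compound, gives a 1.2-fold higher number from compound 1 to compound 3 (0.06 log units; within the scatter) so all three substituted phenyl groups on this amine nitrogen read alike. Going from one chlorine to two thus leaves the number within the scatter, as the earlier exchange of one substituted phenyl for another did. Nothing available explains this sameness. As far as these compounds go, all three groups here are substituted phenyl rings, so it remains open whether the number would hold with a very different group, such as a pyridine ring, a carboxylic acid or a short alkyl chain.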